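The source may report more compounds than this note shows. Statements on the series, on what has been measured and on what is new or still open speak of the compounds shown alone.

In an ADME assay on HT-29 cells (Homo sapiens) for cytotoxicity, read by MTT assay, with a stated time of 72 h (on this read-out higher numbers stand for weaker inhibition and lower numbers for stronger inhibition), compound 1 `C=CC(=O)Nc1cc(Nc2ncc3ncn(-c4ccccc4)c3n2)c(OC)cc1N(C)CCN(C)C` gives 8080 nM. Compound 2 `C=CC(=O)Nc1cc(Nc2ncc3ncn(-c4ccc(C)cc4)c3n2)c(OC)cc1N(C)CCN(C)C`, which carries methyl in place of hydrogen on an aromatic carbon, gives 9230 nM, and compound 3 `C=CC(=O)Nc1cc(Nc2ncc3ncn(-c4ccc(F)cc4)c3n2)c(OC)cc1N(C)CCN(C)C`, which carries fluoro in place of hydrogen on an aromatic carbon, gives 12000 nM. The step of a 1.5-fold higher number from compound 1 to compound 3 (0.17 log units; within the scatter) and the step of a 1.3-fold higher number from compound 2 to compound 3 (0.11 log units; within the scatter) both stay within the scatter, so compound 3 sits level with compounds 1 and 2. Compound 4 `C=CC(=O)Nc1cc(Nc2ncc3ncn(-c4ccc(I)cc4)c3n2)c(OC)cc1N(C)CCN(C)C` differs from compound 3 by iodo in place of fluoro on an aromatic carbon. Because the steps of a 1.5-fold higher number from compound 1 to compound 3 (0.17 log units; within the scatter) and a 1.3-fold higher number from compound 2 to compound 3 (0.11 log units; within the scatter) at this same aromatic carbon moved nothing beyond the scatter, another swap of the group there is expected to leave the number essentially unchanged; the estimated step is no change at the digits printed from compound 3 to compound 4 (within the scatter). Compound 4 is therefore expected to give about 12000 nM, with a likely range from 6000 nM to 24000 nM.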

Compound 4, half-maximal inhibitory concentration: 9520 nM
Compound 4: middle estimate off by 1.3-fold (0.10 log units), on the high side; the range from low to high includes it.
By their numbers in this assay, from the lowest: compounds 1, 2, 4 and 3 (each within the scatter of the next).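

In this assay the iodo group also stays level with the other groups at this aromatic carbon: a 1.3-fold lower number from compound 3 to compound 4 (0.10 log units; within the scatter) and a 1.0-fold higher number from compound 2 to compound 4 (0.01 log units; within the scatter) and a 1.2-fold higher number from compound 1 to compound 4 (0.07 log units; within the scatter) all lie within the scatter. Hydrogen, methyl, fluoro and iodo at this place therefore give numbers that cannot be told apart, and this flat picture now reaches from the smallest halogen shown to iodo. No measurement at hand accounts for this flatness.

The compounds shown leave open whether an amine, a carboxylic acid or a longer chain at this carbon would also leave the number level.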